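A few compounds are considered here, and "the series" means these few. Any claim that something is new, unique, unknown or untested is made for them only; others in the source may bear on it.

Measured compounds:
compound 1 `Cc1cc(=O)oc2cc(OCc3cn(-c4ccccc4Cl)nn3)ccc12`: > 100 ug/mL
compound 2 `COc1cc(-n2cc(COc3ccc4c(C)cc(=O)oc4c3)nn2)cc(OC)c1OC`: > 100 ug/mL

Both measured compounds were tested in an ADME assay on Huh-7 cells (Homo sapiens) for cytotoxicity, read by MTT assay, with a stated time of 72 h; a higher number here means that more compound is tolerated, a lower number that less compound is tolerated. Compound 1 gives > 100 ug/mL there, which is a limit of the assay rather than a number. Compound 2 likewise gives > 100 ug/mL, again only a limit. Within the data shown here, compound 1 therefore stands at the top of what the assay can report, and the one further value shown sits at the same place, as the limit of > 100 ug/mL in this assay, at which 2 of the 2 values shown sit, records. Among the measured compounds shown here, no pair of measured compounds differs in a single place, so no measured step is available to say how a change at this position moves the read-out.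

Compound 3 `COC(=O)Cn1cc(COc2ccc3c(C)cc(=O)oc3c2)nn1` is not yet measured in this assay. It differs from compound 1 in one place: (methoxycarbonyl)methyl in place of 2-chlorophenyl on an aromatic nitrogen. With both measured values sitting at the same limit, the step expected here, a step that the limit leaves unreadable from compound 1 to compound 3, is none beyond the usual scatter, and compound 3 is most likely to return a limit as well. Compound 3 is accordingly estimated at 150 ug/mL, with a range from 80 ug/mL to 300 ug/mL.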

Compound 3, half-maximal cytotoxic concentration: > 100 ug/mL
Compound 3 gave a limit, no number; the forecaster's own chance of this, stated with the estimate: 85%; the middle value lies beyond the limit too.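

In this assay compound 3 returns only a limit, as compound 1 does, so no step from compound 1 to compound 3 can be read: the limit of > 100 ug/mL in this assay, at which 3 of the 3 values shown sit.

The compounds shown leave open whether (methoxycarbonyl)methyl and 2-chlorophenyl on the aromatic nitrogen differ at all in this assay, and at what concentration any of these compounds would become cytotoxic.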